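The source may report more compounds than this note shows. Statements on the series, on what has been measured and on what is new or still open speak of the compounds shown alone.

Measured compounds:
Compound 1, `C/N=C(\S)NCCCCn1nc(C)ccc1=O`, in a functional assay on the whole organism with Rattus norvegicus as the target, at a dose of 100 mg/kg (on this read-out higher numbers stand for more inhibition at the one dose given (going by the name of the read-out) and lower numbers for less inhibition), compound 1 gives 44.5%.
Compound 2, `CC/N=C(\S)NCCCCCCn1nc(-c2ccccc2)ccc1=O`, in this assay compound 2 gives -5.6%.
Compound 3, `C/N=C(/NC#N)NCCCCCCn1nc(-c2ccccc2)ccc1=O`, in this assay compound 3 gives 31.7%.

Compound 2 stands lowest of the three numbers in this assay; the nearest to it is compound 3, and the furthest is compound 1, and both gaps lie beyond the scatter. Compound 4, `CC/N=C(/NC#N)NCCCCn1nc(-c2ccccc2)ccc1=O`, has not yet been measured. It differs from compound 2 in one place: a group of 8 heavy atoms (4 carbon, 4 nitrogen; no ring) in place of a group of 8 heavy atoms (5 carbon, 2 nitrogen, 1 sulfur; no ring), on a saturated chain carbon, four bonds along the chain from an aromatic nitrogen.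

Going by the values given here, one measured step bears on this change. In this assay the step of a number 37.3 percentage points higher from compound 2 to compound 3 (beyond the scatter) shows what replacing the thiourea part by a cyanoguanidine part does on the longer chain. Among the compounds with values here, compound 1, with the shorter chain and a thiourea part, gives 44.5% in this assay, but no single step links it to compound 2. A step upward in this assay, of a size near that seen from compound 2 to compound 3, is therefore expected: the step of a number 38.6 percentage points higher from compound 2 to compound 4 (beyond the scatter) is the estimate. On that basis compound 4 is expected to give about 33% in this assay, within a range from 12% to 54%.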

Compound 4, a percentage reported as inhibition, in the whole organism at one dose (the size of the read-out at that dose, not a potency): 58.8%
Estimate against measurement, compound 4: 25.8 percentage points below; the whole stated range lies below it.
By their numbers in this assay, from the lowest: compound 2; then compound 3; then compound 1; then compound 4.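

In this assay the change on a saturated chain carbon, four bonds along the chain from an aromatic nitrogen, gives a number 64.4 percentage points higher from compound 2 to compound 4 (beyond the scatter) and so brings a shorter chain and a cyanoguanidine part in place of the thiourea part in one move. Set beside a number 37.3 percentage points higher from compound 2 to compound 3 (beyond the scatter) on the longer chain, it shows an upward step from compound 2 with the cyanoguanidine part at both chain lengths, so the earlier gain is not confined to the longer chain. Nothing given here accounts for the size of this step.

The shares of the chain length and the end group in this step remain unseparated, since the thiourea part with the shorter chain and the phenyl group is not among the compounds shown. Going by these compounds, how a urea part or a propyl group on the cyanoguanidine part would read also stays open.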